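Triazole aryl swap on two oxime-linked triterpene cores

The source may hold more compounds than are shown below. What is called first, only, known or untested is meant among the compounds shown, and "the series" means these compounds.

Compound 1 `COc1cc(OC)c(-n2cc(CO/N=C3\CC[C@]4(C)[C@@H](CC/C=C(\C)CC/C=C(\C)CCC=C(C)C)[C@](C)(O)CC[C@H]4C3(C)C)nn2)c(OC)c1` and compound 2 `CC(C)=CCC/C(C)=C/CC/C(C)=C/CC[C@@H]1[C@@]2(C)CC/C(=N\OCc3cn(-c4ccncc4)nn3)C(C)(C)[C@@H]2CC[C@@]1(C)O` share one core and differ only in the group on the triazole: pyridin-4-yl in place of 2,4,6-trimethoxyphenyl on an aromatic nitrogen. In a functional assay on A549 cells (Homo sapiens) for cytotoxicity, read by MTT assay, with a stated time of 48 h (a higher number here means a weaker inhibitor, a lower number a stronger inhibitor), compound 1 gives 8120 nM, while compound 2 gives 13000 nM, so the step of a 1.6-fold higher number from compound 1 to compound 2 (0.20 log units; within the scatter). Compound 3 `COc1cc(OC)c(-n2cc(COc3ccc(/C=C4\C[C@]5(C)[C@@H](CC/C=C(\C)CC/C=C(\C)CCC=C(C)C)[C@](C)(O)CC[C@H]5C(C)(C)C4=O)cc3)nn2)c(OC)c1` carries the same trimethoxyphenyl-triazole on a different core; the difference between the two cores is not broken down here. Compound 3 gives 16100 nM in this assay, a value within the scatter of both compound 1 and compound 2. Compound 4 `CC(C)=CCC/C(C)=C/CC/C(C)=C/CC[C@@H]1[C@@]2(C)C/C(=C\c3ccc(OCc4cn(-c5ccncc5)nn4)cc3)C(=O)C(C)(C)[C@@H]2CC[C@@]1(C)O` applies the same change to compound 3: pyridin-4-yl in place of 2,4,6-trimethoxyphenyl on an aromatic nitrogen. Because the earlier step of a 1.6-fold higher number from compound 1 to compound 2 (0.20 log units; within the scatter) stayed within the scatter, a similar step a 1.5-fold higher number from compound 3 to compound 4 (0.17 log units; within the scatter) is expected here. For compound 4 the estimate in this assay is 24000 nM, with a likely range from 10000 nM to 60000 nM.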

Compound 4, half-maximal inhibitory concentration: 34000 nM
Beside the measured number, compound 4's estimate is 1.4-fold (0.15 log units) below it; the measured number falls inside the stated range.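

In this assay, pyridin-4-yl in place of 2,4,6-trimethoxyphenyl gives a 2.1-fold higher number from compound 3 to compound 4 (0.32 log units; beyond the scatter). The size of the change carries from one core to the other, with no difference between the two steps that can be separated from the noise: the same change on two cores in this assay, a 1.6-fold higher number (0.20 log units; within the scatter) from compound 1 to compound 2 and a 2.1-fold higher number (0.32 log units; beyond the scatter) from compound 3 to compound 4, 1.3-fold (0.12 log units) apart, within the scatter of two such steps. Among the compounds shown here, this rests on only two pairs, and only the second step lies beyond the scatter, so it shows neither that the change would behave the same way on a further core nor why the number moves.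

The compounds shown leave open whether the ring nitrogen of the pyridine or the loss of the methoxy groups accounts for the step. A plain phenyl, an aminophenyl or a carboxyphenyl on the triazole would help to separate the two.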